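This account rests on a few compounds, and the source may have more. Where it says the series, first, only, none or still open, it means among the compounds named here.

Two compounds carry numbers in a functional assay on CHO cells for agonist activity at sphingosine 1-phosphate receptor 2 (Homo sapiens), read by fluorescence and calcium flux, with a stated time of 3 min; a higher number here means a weaker inhibitor, a lower number a stronger inhibitor. Compound 1, `Cc1cc(NNC(=O)Nc2cc(Cl)nc(Cl)c2)nc(-c2cnn(C)c2)c1`, gives > 23000 nM in this assay, and that is a limit of the assay rather than a measured number. Compound 2, `Cc1cc(CNC(=O)Nc2cc(Cl)nc(OCC(F)F)c2)nnc1-c1cn(C)nc1C(F)(F)F`, gives 5100 nM in this assay, and on the numbers shown it is the only compound with a measured value rather than a limit. Compound 3, `COCCOc1cc(NC(=O)NCc2cc(C)c(-c3cn(C)nc3C(F)(F)F)nn2)cc(Cl)n1`, differs from compound 2 by methoxymethyl in place of difluoromethyl on a saturated chain carbon bound to an oxygen on an aromatic ring. Going by the values given here, no pair of measured compounds differs in this single place, so nothing among the measurements shows how such an exchange shifts the value. The expected step from compound 2 to compound 3 is a 1.0-fold lower number from compound 2 to compound 3 (0.01 log units; within the scatter), a change no larger than the usual scatter and with no set direction. Compound 3 is estimated at 5000 nM in this assay, with a range from 1500 nM to 17000 nM.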

Compound 3, half-maximal inhibitory concentration: 3500 nM
The estimate for compound 3 lay 1.4-fold (0.15 log units) above the measured number, within the range that was stated.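

The first exchange read at this place, methoxymethyl in place of difluoromethyl on a saturated chain carbon bound to an oxygen on an aromatic ring, comes out in this assay as a 1.5-fold lower number from compound 2 to compound 3 (0.16 log units; within the scatter) and so cannot be told apart from repeat measurement. This place therefore accepts a group with one hydrogen-bond acceptor in place of one with none, and the two groups have the same count of heavy atoms, without a shift that the assay can resolve. One exchange of this kind says nothing about other groups, however, and both compounds keep the same core.

On these data alone, whether an amine, a carboxylic acid or a longer chain at this place would move the number beyond the scatter stays open, as does whether the same exchange would read alike on a different core. No measurement shown gives a reason for this result.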